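From 3,5-difluorophenyl to 4-chloro-3-fluorophenyl at the assay limit

The source may report more compounds than this note shows. Statements on the series, on what has been measured and on what is new or still open speak of the compounds shown alone.

Three relatives share one core and differ only in the ring group on the nitrogen: compound 1 `C=C[C@@](C)(/C=C/c1ccc(Nc2ccccc2)cc1)CCC=C(C)C`, compound 2 `C=C[C@@](C)(/C=C/c1ccc(Nc2ccc(F)c(F)c2)cc1)CCC=C(C)C` and compound 3 `C=C[C@@](C)(/C=C/c1ccc(Nc2cc(F)cc(F)c2)cc1)CCC=C(C)C`. In a functional assay on Raji cells (Homo sapiens) for cytotoxicity, with a stated time of 72 h (on this read-out lower numbers stand for an effect already at smaller amounts and higher numbers for an effect only at larger amounts of compound), compound 1 gives > 26000 nM as a limit of the assay, not a number. Compound 2 gives > 26000 nM as a limit too. Compound 3, the starting point here, gives > 26000 nM as a limit as well. So the whole series so far comes down to the limit of > 26000 nM in this assay, at which 3 of the 3 values shown sit, and nothing finer.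

Compound 4 `C=C[C@@](C)(/C=C/c1ccc(Nc2ccc(Cl)c(F)c2)cc1)CCC=C(C)C` carries 4-chloro-3-fluorophenyl in place of 3,5-difluorophenyl on a nitrogen on an aromatic ring, a single change: 4-chloro-3-fluorophenyl in place of 3,5-difluorophenyl on a nitrogen on an aromatic ring and the rest of the structure stays the same.

Going by the values given here, three measured steps bear on this swap, and none of them offers a size: a step that the two limits leave unreadable from compound 1 to compound 3 and a step that the two limits leave unreadable from compound 1 to compound 2 and also a step that the two limits leave unreadable from compound 2 to compound 3 in the same family. They give no direction to carry forward, so no readable shift is expected in this assay and compound 4 is expected to stay with its relatives. The expected step is a step that the limit leaves unreadable from compound 3 to compound 4 and it rests on very little. For compound 4 the estimate is 30000 nM within an expected range of 15000 nM to 60000 nM and the assay will most likely report only a limit again.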

Compound 4, half-maximal effective concentration: > 26000 nM
Compound 4 gave a limit, no number; the forecaster's own chance of this, stated with the estimate: 85%; the middle value lies beyond the limit too.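

In this assay compound 4 gives > 26000 nM, a limit and not a number. Its steps from compound 1, compound 2 and compound 3 therefore cannot be read, and the series stays where it was: the limit of > 26000 nM in this assay, at which 4 of the 4 values shown sit.

The compounds shown leave open whether any ring group on the nitrogen can give a measurable value in this assay.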